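Aryl variation on the carbonyl carbon of the shared core

The source may hold more compounds than are shown below. What is called first, only, known or untested is meant among the compounds shown, and "the series" means these compounds.

Measured in a functional assay on SR cells (Homo sapiens) for inhibition, read by sulforhodamine B assay, with a stated time of 48 h; on this read-out higher numbers stand for weaker inhibition of growth and lower numbers for stronger inhibition of growth:
compound 1 `COc1cc(-c2cc(/C=C/C(=O)c3ccc(N)cc3)[nH]n2)cc(OC)c1OC`: 320 nM
compound 2 `COc1cc(-c2cc(/C=C/C(=O)c3ccc(Cl)c(Cl)c3)[nH]n2)cc(OC)c1OC`: 390 nM
compound 3 `COc1ccc(C(=O)/C=C/c2cc(-c3cc(OC)c(OC)c(OC)c3)n[nH]2)cc1`: not yet measured

Among the measured compounds shown here, compound 2 gives the highest of the two numbers so far, its nearest neighbour being compound 1, and the difference between them is small: a 1.2-fold higher number from compound 1 to compound 2 (0.09 log units; within the scatter). For the measured compounds named here, both carry the same core and differ only in the aryl group on the carbonyl carbon, so the series so far suggests that this position tolerates exchange of the aryl group without a shift beyond the scatter.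

Compound 3 is reached from compound 2 by 4-methoxyphenyl in place of 3,4-dichlorophenyl on a carbonyl carbon. Going by the values given here, the only step that bears on this change is the one from compound 1 to compound 2, which was itself within the scatter, and it is the sole precedent for an aryl swap on the carbonyl carbon. On that basis no step beyond the scatter is expected in this assay for compound 3, in either direction. The estimate for compound 3 is therefore 350 nM, with a range of 150 nM to 800 nM, corresponding to an expected step of a 1.1-fold lower number from compound 2 to compound 3 (0.05 log units; within the scatter).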

Compound 3, concentration for 50% growth inhibition: 340 nM
Compound 3: the middle estimate sits 1.0-fold (0.01 log units) above what was measured; low and high end bracket the measured number.
By their numbers in this assay, from the lowest: compounds 1, 3 and 2 (each within the scatter of the next).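

In this assay the exchange of 3,4-dichlorophenyl for 4-methoxyphenyl on the carbonyl carbon gives a 1.1-fold lower number from compound 2 to compound 3 (0.06 log units; within the scatter) and so provides a second aryl swap at this place that stays within the scatter, this time with chlorine gone and a group carrying a hydrogen-bond acceptor in its stead. The exchange of amino for methoxy on an aromatic carbon gives a 1.1-fold higher number from compound 1 to compound 3 (0.03 log units; within the scatter) and closes the set, so that 4-aminophenyl, 3,4-dichlorophenyl and 4-methoxyphenyl on the carbonyl carbon are not separated from one another on this read-out. Nothing measured on these compounds accounts for this absence of separation.

As far as these compounds go, all three groups on the carbonyl carbon are substituted six-membered aromatic rings of carbon only, so it remains open whether a carboxylic acid on that ring, or a longer alkyl chain in place of the ring, would stay within the same band. Also open, from the compounds shown here alone, is how the number responds to changes elsewhere on the shared core, such as an amine in place of one of its methoxy groups.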